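This account rests on a few compounds, and the source may have more. Where it says the series, first, only, none or still open, it means among the compounds named here.

Measured so far:
compound 1, `COc1cc(Nc2nc3ccccc3nc2S(=O)(=O)c2ccccc2)cc(OC)c1`: 70 nM
compound 2, `Nc1ccc(Nc2nc3ccccc3nc2S(=O)(=O)c2ccccc2)cc1`: 12900 nM
compound 3, `COc1cc(Nc2nc3ccccc3nc2S(=O)(=O)c2ccc(F)cc2)cc(OC)c1`: 5450 nM

All three were tested in a functional assay on A549 cells (Homo sapiens) for cytotoxicity, read by MTT assay, with a stated time of 72 h; a lower number here means a stronger inhibitor, a higher number a weaker inhibitor. Compound 1 is the starting point, and each of the other two departs from it in one place. Compound 2 carries the change (4-aminophenyl in place of 3,5-dimethoxyphenyl on a nitrogen on an aromatic ring), and the step is a 180-fold higher number from compound 1 to compound 2 (2.27 log units; beyond the scatter). Compound 3 carries the change (fluoro in place of hydrogen on an aromatic carbon), and the step is a 78-fold higher number from compound 1 to compound 3 (1.89 log units; beyond the scatter). Both single changes therefore weaken the compound considerably, and compound 2 and compound 3 end up fairly close to one another, compound 2 the higher of the two.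

Compound 4, `Nc1ccc(Nc2nc3ccccc3nc2S(=O)(=O)c2ccc(F)cc2)cc1`, has not been measured. It differs from compound 3 by 4-aminophenyl in place of 3,5-dimethoxyphenyl on a nitrogen on an aromatic ring. This is the same change that was made from compound 1 to compound 2, made here on a core that differs from that of compound 1 by fluoro in place of hydrogen on an aromatic carbon. Whether a change that cost so much on the core of compound 1 costs as much again on the core of compound 3 cannot be read from two examples; combining two changes that each weakened the compound would be expected to give the weakest of the set, but the step may well be smaller than the first one, since compound 3 already stands far from compound 1. The step from compound 3 to compound 4 in this assay is expected to be about a 7.3-fold higher number from compound 3 to compound 4 (0.87 log units; beyond the scatter). For compound 4 the estimate in this assay is 40000 nM, with a plausible range from 10000 nM to 200000 nM, and a real chance that only a limit is reported.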

Compound 4, half-maximal inhibitory concentration: 12700 nM
Estimate against measurement, compound 4: 3.1-fold (0.50 log units) above; measured number inside the range.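

In this assay, the change to 4-aminophenyl does not carry over from one core to the other at the same size, as the step shrinks to a 2.3-fold higher number from compound 3 to compound 4 (0.37 log units; beyond the scatter) once the fluoro is present: the same change on two cores in this assay, a 180-fold higher number (2.27 log units; beyond the scatter) from compound 1 to compound 2 and a 2.3-fold higher number (0.37 log units; beyond the scatter) from compound 3 to compound 4, 79-fold (1.90 log units) apart, beyond the scatter of two such steps The fluoro behaves the same way, since with 4-aminophenyl already in place the step is only a 1.0-fold lower number from compound 2 to compound 4 (0.01 log units; within the scatter), so compound 2 and compound 4 cannot be told apart, and its large cost appears only on the core of compound 1: the same change on two cores in this assay, a 78-fold higher number (1.89 log units; beyond the scatter) from compound 1 to compound 3 and a 1.0-fold lower number (0.01 log units; within the scatter) from compound 2 to compound 4, 79-fold (1.90 log units) apart, beyond the scatter of two such steps These two gaps are one finding read from two sides of the same four compounds: the costs of the two changes do not add up here, but this single set cannot say why, or whether the same would hold on any other core in the series.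

From the compounds shown here alone, what stays open is whether the sharp loss is tied to fluoro itself, or whether chloro or methyl in the same place would cost as much on the core of compound 1. Going by these compounds, it is also open whether a phenyl with a single methoxy, or a hydroxyphenyl, in place of 3,5-dimethoxyphenyl would behave like 4-aminophenyl on each core.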